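The source may hold more compounds than are shown below. What is called first, only, known or untested is meant among the compounds shown, and "the series" means these compounds.

Compound 1 `CC(C)c1ccc(Cn2cncc2CNc2ccc(-c3nc4ccccc4s3)c(-c3ccccc3)c2)cc1` and compound 2 `COC(=O)c1ccc(NCc2cncn2Cc2ccc(C(C)(C)C)cc2)cc1-c1ccccc1` share the same core and are screened in a toxicity assay on NIH3T3 cells (Mus musculus) for cytotoxicity, read by resazurin assay; a lower number here means that less compound is needed, a higher number that more compound is needed for the effect. Compound 1 reaches only a limit of this assay, > 1000 nM, which is the limit of > 1000 nM in this assay, at which 1 of the 2 values shown sits. For compound 2 this assay reports "not determined" (no result reported), so compound 2 has no number to stand on. Compound 3 `COC(=O)c1ccc(NCc2cncn2Cc2ccccc2[N+](=O)[O-])cc1-c1ccccc1` differs from compound 2 by one exchange: 2-nitrophenyl in place of 4-(tert-butyl)phenyl on a saturated chain carbon bound to an aromatic nitrogen. Among the compounds with values here, with no measured step between any two compounds here, no size or direction beyond the usual scatter can be expected for this change. Compound 3 is estimated to give 2000 nM in this assay, within 500 nM to 10000 nM.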

Compound 3, half-maximal effective concentration: 10000 nM
Compound 3: middle estimate off by 5.0-fold (0.70 log units), on the low side; low and high end bracket the measured number.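

Compound 2 has no number in this assay, so the exchange to compound 3, which gives 10000 nM, cannot be read as a step. As far as these compounds go, what replacing 4-(tert-butyl)phenyl with 2-nitrophenyl does to this value stays open.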